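Series notes: a second chloro on compound 2

This account rests on a few compounds, and the source may have more. Where it says the series, first, only, none or still open, it means among the compounds named here.

Three compounds of a shared core have been run in an ADME assay on Raji cells (Homo sapiens) for cytotoxicity, with a stated time of 72 h; a higher number here means that more compound is needed for the effect, a lower number that less compound is needed. Compound 1 `Cc1cc(NC(=O)Nc2ccc(N)cc2)c2ccccc2n1` sits at > 25000 nM, a limit of the assay rather than a number. Compound 3 `Cc1cc(NC(=O)Nc2ccccc2N)c2ccccc2n1` likewise sits at > 25000 nM, again a limit. Going by the values given here, compound 2 `Cc1cc(NC(=O)Nc2cccc(Cl)c2)c2ccccc2n1` is the only one with a number, giving 18000 nM in this assay, and so stands alone among the values shown. The step of an at least 1.3-fold lower number from compound 1 to compound 2 (0.14 log units; that floor lies within the scatter) and the step of an at least 1.3-fold higher number from compound 2 to compound 3 (0.14 log units; that floor lies within the scatter) are each readable only as a floor that lies within the scatter, and a step that the two limits leave unreadable from compound 1 to compound 3 cannot be read at all, which follows from the limit of > 25000 nM in this assay, at which 2 of the 3 values shown sit.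

Compound 4 `Cc1cc(NC(=O)Nc2ccc(Cl)c(Cl)c2)c2ccccc2n1` has not been measured. It differs from compound 2 by chloro in place of hydrogen on an aromatic carbon. Among the compounds with values here, none of the measured steps adds a chloro group; the two steps that touch compound 2 exchange the whole substituent on the amide-type nitrogen and move the number only within the scatter. No step beyond the scatter is therefore expected in this assay, with a slight lowering left open. Compound 4 is expected to give 12000 nM, between 4000 nM and 30000 nM, which means a 1.5-fold lower number from compound 2 to compound 4 (0.18 log units; within the scatter).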

Compound 4, half-maximal effective concentration: 10000 nM
Compound 4: middle estimate off by 1.2-fold (0.08 log units), on the high side, and the stated range covers the measured number.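

Going by these compounds alone, this is the first step with a number at both ends, whereas the earlier steps gave only floors or could not be read. It is also the first to change a single aromatic carbon, ortho to a chloro group and para to a large group, rather than exchange the whole substituent on the amide-type nitrogen. In this assay, the step is a 1.8-fold lower number from compound 2 to compound 4 (0.26 log units; within the scatter), so this position takes a chloro group without any change that can be told from the scatter.

Going by these compounds, a single chloro result does not show whether this position is insensitive in general, and it remains open whether a methoxy group, an amine or a carboxylic acid at the same place would give a step beyond the scatter. The steps that end at a limit stay poorly defined or cannot be read, so the chloro compounds cannot be set firmly against the amino compounds, because the limit hides how far those values lie: the limit of > 25000 nM in this assay, at which 2 of the 4 values shown sit.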